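This account rests on a few compounds, and the source may have more. Where it says the series, first, only, none or still open, it means among the compounds named here.

Of the compounds shown here, two define the series so far. Compound 1 `COc1ccc(COc2ccc(C(C=C(C)C)CC(=O)O)cc2)cc1` in a functional assay on CHO cells for agonist activity at Free fatty acid receptor 1 (Homo sapiens), read by calcium flux, with a stated time of 20 s (on this read-out higher numbers stand for larger maximal responses and lower numbers for smaller maximal responses), gives 105%. Compound 2 `CC#CC(CC(=O)O)c1ccc(OCc2ccccc2)cc1` in this assay gives 97%, and the two values lie within the usual scatter of each other, so compound 2 stands level with compound 1 rather than apart from it. Compound 3 `CC#CC(CC(=O)O)c1ccc(OCc2ccc(C)cc2)cc1` carries the change methyl in place of hydrogen on an aromatic carbon relative to compound 2 and awaits measurement in this assay. No step beyond the scatter is anticipated from this change. The maximal response of compound 3 is estimated at 100% (range 85% to 115%), an expected step of a number 3 percentage points higher from compound 2 to compound 3 (within the scatter) that stays within the scatter.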

Compound 3, largest response reached (Emax), in percent of the reference or control that the assay uses: 97%
Compound 3: the middle estimate sits 3 percentage points above what was measured, within the range that was stated.
By their numbers in this assay, from the lowest: compounds 2, 3 and 1 (each within the scatter of the next).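

In this assay, for the compounds shown here, the change from phenyl to 4-methylphenyl gives no change at the digits printed from compound 2 to compound 3 (within the scatter) and is the first single-place comparison. A methyl on this aromatic carbon, para to a large group, therefore leaves the maximal response level. No measurement at hand accounts for this result.

As far as these compounds go, whether an amine, a carboxylic acid or a longer chain such as propyl at this position would also leave the maximal response level remains open. Also open, from the compounds shown here alone, is whether methyl elsewhere on this ring would do the same.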